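Restoring the aryl amide in place of the sulfonyl group

The compounds below may be only part of what the source reports. "The series", "measured", "known", "first", "only" and "open" are said of these compounds alone.

Of the compounds shown here, three sharing one core have been measured in an assay on isolated protein for inhibition of Rho-associated protein kinase 2 (Homo sapiens), read by scintillation counting, radiometric assay and 33P incorporation, with a stated time of 40 min, in the presence of a further agent that is not named here; a lower number here means a stronger inhibitor, a higher number a weaker inhibitor. Compound 1 `N#Cc1ccc(C(=O)Nc2cccc(NC(=O)COc3ccc4c(=O)ccoc4c3)c2)cc1` gives 15 nM, compound 2 `Cc1cc(C(=O)Nc2cccc(NC(=O)COc3ccc4c(=O)ccoc4c3)c2)ccc1C(F)(F)F` gives 43 nM, and compound 3 `Cn1ccc(S(=O)(=O)Nc2cccc(NC(=O)COc3ccc4c(=O)ccoc4c3)c2)n1` gives 1350 nM. Compound 3 therefore stands highest of the three numbers, with a weaker inhibition than either of the others. Compound 4 `Nc1ccc(C(=O)Nc2cccc(NC(=O)COc3ccc4c(=O)ccoc4c3)c2)cc1` differs from compound 3 by a group of 9 heavy atoms (7 carbon, 1 nitrogen, 1 oxygen; one six-membered aromatic ring of carbon only) in place of a group of 9 heavy atoms (4 carbon, 2 nitrogen, 2 oxygen, 1 sulfur; one five-membered aromatic ring with 2 hetero atoms), on a nitrogen on an aromatic ring.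

Among the compounds with values here, two measured steps bear on this change. The step of a 90-fold higher number from compound 1 to compound 3 (1.95 log units; beyond the scatter) shows that exchanging an aryl carbonyl for the sulfonyl-linked five-membered ring cost a great deal, and compound 4 reverses exactly that kind of exchange. The step of a 2.9-fold higher number from compound 1 to compound 2 (0.46 log units; beyond the scatter) shows that varying the substituents on the aryl carbonyl moved the number only modestly. A large step downward in this assay is therefore expected, a 45-fold lower number from compound 3 to compound 4 (1.65 log units; beyond the scatter), landing compound 4 close to the region of compound 1 and compound 2. Compound 4 is estimated at 30 nM, within a range of 8 nM to 120 nM.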

Compound 4, half-maximal inhibitory concentration: 83 nM
The estimate for compound 4 lay 2.8-fold (0.44 log units) below the measured number; the measured number falls inside the stated range.
By their numbers in this assay, from the lowest: compound 1; then compounds 2 and 4 (each within the scatter of the next); then compound 3.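

In this assay, the (4-aminophenyl)carbonyl group on the nitrogen recovers much of what the sulfonyl-linked five-membered ring had lost (a 16-fold lower number from compound 3 to compound 4 (1.21 log units; beyond the scatter)), so the large gap is not confined to the nitrile-bearing compound. The substituent on the aryl carbonyl still counts: amino in place of cyano gives a modest loss (a 5.5-fold higher number from compound 1 to compound 4 (0.74 log units; beyond the scatter)). The comparison with the methyl and trifluoromethyl pattern stays within the scatter (a 1.9-fold higher number from compound 2 to compound 4 (0.29 log units; within the scatter)), so these two compounds cannot be ordered.

The step from compound 3 to compound 4 changes both the linking group and the ring, so the shown compounds leave open how much each contributes, which a sulfonyl-linked benzene ring or a carbonyl-linked pyrazole could separate, as well as how a carboxylic acid or a dimethylamino group would compare with the amino group. Nothing given here accounts for the size of these steps.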